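Benzophenone acid series: cyclohexyl ketone in place of aryl

The source may report more compounds than this note shows. Statements on the series, on what has been measured and on what is new or still open speak of the compounds shown alone.

Measured so far:
compound 1 `O=C(O)c1ccc(C(=O)c2ccc(C(=O)c3ccc(C(=O)O)cc3)cc2)cc1` gives 1000 nM in an assay on CHO cells for inhibition of 3-oxo-5-alpha-steroid 4-dehydrogenase 2 (Homo sapiens); a higher number here means a weaker inhibitor, a lower number a stronger inhibitor
compound 2 `O=C(O)c1ccc(C(=O)c2ccc(C(=O)c3ccccc3)cc2)cc1` gives 40 nM in this assay
compound 3 `O=C(O)c1ccc(C(=O)c2ccc(C(=O)c3ccc(Cl)cc3Cl)cc2)cc1` gives 35 nM in this assay

Compound 3 holds the lowest of the three numbers, but the gap to compound 2 is within the scatter (a 1.1-fold lower number from compound 2 to compound 3 (0.06 log units; within the scatter)), so the two cannot be ordered; compound 1 sits well apart (a 29-fold lower number from compound 1 to compound 3 (1.46 log units; beyond the scatter)), as does the parallel step to compound 2 (a 25-fold lower number from compound 1 to compound 2 (1.40 log units; beyond the scatter)).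

Compound 4 `O=C(O)c1ccc(C(=O)c2ccc(C(=O)C3CCCCC3)cc2)cc1` differs from compound 3 by cyclohexyl in place of 2,4-dichlorophenyl on a carbonyl carbon. Going by the values given here, no measured step exchanges an aromatic ring for a non-aromatic one, so nothing bears directly on this change. The large steps both concern the carboxy group, which compound 4 keeps. Among the compounds with values here, the only step touching the terminal ring, from compound 2 to compound 3, stayed within the scatter, which argues for a modest step here, if any, with the direction uncertain. Compound 4 is therefore expected near 60 nM, within 15 nM to 250 nM, an estimated step of a 1.7-fold higher number from compound 3 to compound 4 (0.23 log units; within the scatter).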

Compound 4, inhibition constant: 30 nM
Compound 4: middle estimate off by 2.0-fold (0.30 log units), on the high side; the measured number falls inside the stated range.
By their numbers in this assay, from the lowest: compounds 4, 3 and 2 (each within the scatter of the next); then compound 1.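

Aromaticity of the terminal ring on this carbonyl carbon is not required in the compounds shown: in this assay, cyclohexyl in place of 2,4-dichlorophenyl (a 1.2-fold lower number from compound 3 to compound 4 (0.07 log units; within the scatter)) and cyclohexyl in place of phenyl (a 1.3-fold lower number from compound 2 to compound 4 (0.12 log units; within the scatter)) both stay within the scatter. The large change remains tied to the 4-carboxyphenyl group, with cyclohexyl in its place (a 33-fold lower number from compound 1 to compound 4 (1.52 log units; beyond the scatter)) matching the earlier large steps away from that group. No supporting data explain why the non-aromatic ring is tolerated here.

Open-chain groups at this position, such as tert-butyl or pentyl, remain untested in the compounds shown. Also open, going by these compounds, is whether a cyclohexyl ring carrying a carboxylic acid or an amine would stay with compound 4 or move toward compound 1.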